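Chloro to fluoro on the aryl ring of compound 2

The compounds below may be only part of what the source reports. "The series", "measured", "known", "first", "only" and "open" are said of these compounds alone.

Measured so far:
compound 1 `Cc1cc(CN(CC2CC2)C(CC(=O)O)c2ccc(Cl)cc2)ccc1OCCn1c(=O)ccn(C)c1=O`: 91 nM
compound 2 `COc1cc(CN(CC(C)C)C(CC(=O)O)c2ccc(Cl)c(Cl)c2)ccc1OCCN1C(=O)CCC1=O`: 143 nM

In an assay on CHO cells for displacement of a labelled ligand from C-X-C chemokine receptor type 3 (Homo sapiens), with a stated time of 60 min (a higher number here means a weaker inhibitor, a lower number a stronger inhibitor), compound 1 gives 91 nM and compound 2 gives 143 nM. Of these two numbers, compound 2 holds the higher one, but the gap to compound 1 is within the scatter, so the two are not separated. Compound 3 `COc1cc(CN(CC(C)C)C(CC(=O)O)c2ccc(Cl)c(F)c2)ccc1OCCN1C(=O)CCC1=O` differs from compound 2 by fluoro in place of chloro on an aromatic carbon, the change reading 3,4-dichlorophenyl to 4-chloro-3-fluorophenyl. Going by the values given here, no comparable step has been measured. The step of a 1.4-fold higher number from compound 2 to compound 3 (0.15 log units; within the scatter) is expected to be small, at most a slight rise in this assay. Compound 3 is therefore estimated at 200 nM, with a range from 80 nM to 500 nM.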

Compound 3, half-maximal inhibitory concentration in the C-X-C chemokine receptor type 3 assay: 70 nM
Compound 3: middle estimate off by 2.9-fold (0.46 log units), on the high side, outside the stated range (below it).
By their numbers in the C-X-C chemokine receptor type 3 assay, from the lowest: compounds 3, 1 and 2 (each within the scatter of the next, the first and the last beyond it).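

Going by these compounds alone, in the C-X-C chemokine receptor type 3 assay, fluoro in place of chloro on this aromatic carbon, ortho to a chloro group, gives a 2.0-fold lower number from compound 2 to compound 3 (0.31 log units; beyond the scatter), with compound 2 at 143 nM and compound 3 at 70 nM, the first single-place step, so the chloro here can be replaced without loss in this assay. In a physicochemical assay for solubility, at pH 1.1 (a lower number here means a less soluble compound, a higher number a more soluble compound), the same change gives no change at the digits printed from compound 2 to compound 3 (within the scatter), with compound 2 at 3000000 nM and compound 3 at 3000000 nM. Nothing measured accounts for either result. Still open, going by these compounds, is whether a nitrile or a trifluoromethyl group at this position would lower the number further. Also open, on these data alone, is whether the step carries over to the core of compound 1.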